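The source may report more compounds than this note shows. Statements on the series, on what has been measured and on what is new or still open speak of the compounds shown alone.

Measured compounds:
Compound 1, `Cn1c(Cc2ccccc2C(F)(F)F)nc(C(=O)Nc2ccccc2)c(O)c1=O`, in an ADME assay on HepG2 cells (Homo sapiens) for cytotoxicity, in the presence of a further agent that is not named here (on this read-out lower numbers stand for stronger inhibition and higher numbers for weaker inhibition), gives > 100000 nM, which is a limit of the assay rather than a number.
Compound 2, `Cn1c(Cc2ccccc2C(F)(F)F)nc(C(=O)CCc2ccccc2)c(O)c1=O`, in this assay gives > 100000 nM, again a limit of the assay and not a number.

For the measured compounds named here, compound 2 therefore stands only at a limit in this assay, and the one further value shown is a limit as well, so that the limit of > 100000 nM in this assay, at which 2 of the 2 values shown sit, covers everything measured so far. Going by the values given here, the only measured step is a step that the two limits leave unreadable from compound 1 to compound 2, and the two limits leave its size unreadable. Compound 3, `Cn1c(Cc2ccccc2C(F)(F)F)nc(C(=O)NCc2ccc(F)cc2)c(O)c1=O`, has not yet been measured. It differs from compound 2 by (4-fluorobenzyl)amino in place of phenethyl on a carbonyl carbon. The measured step bears on this change in that it also exchanged the group on the carbonyl carbon, yet it gives no readable size and no direction. No step beyond the scatter is therefore expected, and the most likely outcome is once more a limit. The estimate for compound 3 in this assay is 150000 nM, with a range from 50000 nM to 500000 nM. The expected step is a step that the limit leaves unreadable from compound 2 to compound 3.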

Compound 3, half-maximal inhibitory concentration: > 100000 nM
Compound 3: only a limit was reported; the forecaster's own chance of this, stated with the estimate: 80%; the middle value does not contradict the limit.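

Compound 3 gives only a limit of the assay in this assay, not a number, and so do compound 1 and compound 2, so no step among these three compounds can be read: the limit of > 100000 nM in this assay, at which 3 of the 3 values shown sit.

The compounds shown leave open whether the group on the carbonyl carbon has any effect in this assay, how large that effect is, and in which direction it runs.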